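This account rests on a few compounds, and the source may have more. Where it says the series, first, only, none or still open, it means among the compounds named here.

Measured so far in a functional assay on KB cells (Homo sapiens) for cytotoxicity; a lower number here means that less compound is needed, a higher number that more compound is needed for the effect:
compound 1 `CCCOc1cc(-c2ccccc2)nc2ccccc12` gives 4.5 ug/mL 
compound 2 `CCCCOc1cc(-c2ccccc2)nc2ccccc12` gives 3.8 ug/mL 

Compound 2 at 3.8 ug/mL cannot be separated from compound 1 and stands level with it within the scatter. These two values are all the series offers so far.

Next comes compound 3 `CC(C)COc1cc(-c2ccccc2)nc2ccccc12` with the difference isopropyl in place of propyl on a saturated chain carbon bound to an oxygen on an aromatic ring to consider. In words, isopropyl stands in place of propyl on a saturated chain carbon bound to an oxygen on an aromatic ring, so butoxy becomes isobutoxy. Among the measured compounds shown here, no measured pair shows this exact kind of change. The nearest guide is a methyl in place of hydrogen on the same chain, which gave a 1.2-fold lower number from compound 1 to compound 2 (0.07 log units; within the scatter) and so offers only indirect support. That single step gives no basis for a direction. The estimated step is a 1.1-fold higher number from compound 2 to compound 3 (0.02 log units; within the scatter) and no change beyond the scatter is expected in either direction. Compound 3 is expected at 4 ug/mL within an estimated range of 2 ug/mL to 8 ug/mL in this assay once measured.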

Compound 3, half-maximal effective concentration: > 4 ug/mL
Compound 3 gave a limit, no number (the forecaster's own chance of this, stated with the estimate: 3%); the middle value lies on the limit itself.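

In this assay compound 3 gives > 4 ug/mL, which is a limit and not a number, the only such entry in the series so far: the limit of > 4 ug/mL in this assay, at which 1 of the 3 values shown sits.

Moving from butoxy to isobutoxy, with propyl replaced by isopropyl on a saturated chain carbon bound to an oxygen on an aromatic ring, gives only a floor and not a measured size: an at least 1.0-fold higher number from compound 2 to compound 3 (0.02 log units; that floor lies within the scatter). Among the compounds shown here, this is the first look at a branched chain at this position, and the floor does not separate compound 3 from compound 2, while leaving its upper side unbounded. The step that joins compound 1 to compound 3 cannot be read.

As far as these compounds go, the true value of compound 3 remains open, so the series cannot yet say whether branching leaves this assay unchanged or moves it beyond the scatter. Also open, from the compounds shown here alone, is how a longer chain such as hexyl, an amine or a carboxylic acid in place of the butoxy chain on the shared core would read in this assay.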